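The compounds below may be only part of what the source reports. "The series", "measured", "known", "first", "only" and "open" are said of these compounds alone.

The series shares the core of compound 1 `COc1ccc(OC)c(/C=N/NC(=O)c2cc(OC)c(OC)c(OC)c2)c1`, which in a functional assay on BGC-823 cells (Homo sapiens) for antiproliferative activity, read by MTT assay, tested at 5 uM (a higher number here means a stronger effect of the compound at the concentration tested, a lower number a weaker effect), gives 10.1%. Compound 2 `COc1cc(C(=O)N/N=C/c2c(Cl)cccc2Cl)cc(OC)c1OC` gives 27.8% in this assay, and compound 3 `COc1cc(C2=NN(C(C)=O)C(c3ccc(Cl)c([N+](=O)[O-])c3)O2)cc(OC)c1OC` gives 0%. On these three numbers compound 2 stands highest, and its distances to compound 1 and to compound 3 both lie beyond the scatter. Compound 4 `COc1cc(C(=O)N/N=C/c2ccc(Cl)c(Cl)c2)cc(OC)c1OC` has not been measured. Against compound 2 it differs in one place: 3,4-dichlorophenyl in place of 2,6-dichlorophenyl on a carbon with a double bond to nitrogen. Within the data shown here, no measured pair shows this change, so no size can be read from the numbers; a shift of moderate size is expected, more likely downward from compound 2 than upward, though either direction remains open. The estimate for compound 4 in this assay is 22%, within 5% to 42%. The step expected from this is a number 5.8 percentage points lower from compound 2 to compound 4 (within the scatter).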

Compound 4, a percentage reported as inhibition, at one concentration (the size of the read-out at that concentration, not a potency): 32.7%
Estimate against measurement, compound 4: 10.7 percentage points below, and the stated range covers the measured number.
By their numbers in this assay, from the lowest: compound 3; then compound 1; then compounds 2 and 4 (each within the scatter of the next).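

Among these compounds, the first pair at this position, on a carbon with a double bond to nitrogen, gives in this assay a step of a number 4.9 percentage points higher from compound 2 to compound 4 (within the scatter). The 2,6-dichlorophenyl and 3,4-dichlorophenyl groups therefore cannot be told apart at this single concentration, and the read-out here tolerates this rearrangement of the two chlorines. Nothing measured speaks to a cause for this result.

Still open, as far as these compounds go, is whether an unsubstituted phenyl, or a phenyl carrying an amine or a carboxylic acid, would hold the read-out at this place. From the compounds shown here alone, whether compound 2 and compound 4 separate at other concentrations also remains open.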